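Amine size on the amide side chain across two scaffolds

The source may hold more compounds than are shown below. What is called first, only, known or untested is meant among the compounds shown, and "the series" means these compounds.

Compound 2 `CCN(CC)CCCNC(=O)c1ccc(C(CC)(CC)c2ccc(OCC(=O)C(C)(C)C)c(C)c2)n1CC` and compound 1 `CCn1c(C(=O)NCCCN(C)C)ccc1C(CC)(CC)c1ccc(OCC(=O)C(C)(C)C)c(C)c1` share one core; compound 3 `CCN(CC)CCNC(=O)c1ccc(C(CC)(CC)c2ccc(OCC(O)C(C)(C)C)c(C)c2)n1CC` and the as yet unmeasured compound 4 `CCn1c(C(=O)NCCN(C)C)ccc1C(CC)(CC)c1ccc(OCC(O)C(C)(C)C)c(C)c1` share another. In a functional assay on HepG2 cells (Homo sapiens), read by MTT assay, with a stated time of 48 h (on this read-out higher numbers stand for weaker inhibition and lower numbers for stronger inhibition), compound 2 gives 180 nM, compound 1 gives 960 nM and compound 3 gives 490 nM. The change dimethylamino in place of diethylamino on a saturated chain carbon, three bonds along the chain from an amide-type nitrogen made the step of a 5.3-fold higher number from compound 2 to compound 1 (0.73 log units; beyond the scatter). The difference between the core of compound 2 and the core of compound 3 is not broken down here. Compound 4 carries dimethylamino in place of diethylamino on a saturated chain carbon, two bonds along the chain from an amide-type nitrogen, the same kind of change, though here the place is two bonds along the chain from an amide-type nitrogen rather than three bonds along the chain from an amide-type nitrogen. Because a 5.3-fold higher number from compound 2 to compound 1 (0.73 log units; beyond the scatter) was seen once, a step of a 4.1-fold higher number from compound 3 to compound 4 (0.61 log units; beyond the scatter) is expected in this assay. Compound 4 is accordingly estimated at 2000 nM, likely between 800 nM and 5000 nM.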

Compound 4, half-maximal inhibitory concentration: 870 nM
The estimate for compound 4 lay 2.3-fold (0.36 log units) above the measured number; the range from low to high includes it.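

On the core of compound 3, dimethylamino in place of diethylamino gives a 1.8-fold higher number from compound 3 to compound 4 (0.25 log units; within the scatter) in this assay, so the change cannot be told from the scatter there. The effect of this change does not carry over in size from one core to the other: the same change on two cores in this assay, a 5.3-fold higher number (0.73 log units; beyond the scatter) from compound 2 to compound 1 and a 1.8-fold higher number (0.25 log units; within the scatter) from compound 3 to compound 4, 3.0-fold (0.48 log units) apart, beyond the scatter of two such steps These two pairs do not show which difference between the cores goes with this gap, and the place of the change also differs, at two rather than three bonds along the chain from an amide-type nitrogen.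

Open, as far as these compounds go, is how a cyclic amine such as piperidine or morpholine would read in place of diethylamino on either core. Also open, from the compounds shown here alone, is whether a longer chain to the amine would keep the larger step.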